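This account rests on a few compounds, and the source may have more. Where it says the series, first, only, none or still open, it means among the compounds named here.

Measured so far in a functional assay on MKN-74 cells (Homo sapiens) for antiproliferative activity, with a stated time of 24 h; on this read-out lower numbers stand for stronger inhibition and higher numbers for weaker inhibition:

Compound 1 `NC(=O)c1c(NC(=O)c2ccccc2Cl)sc2c1CCN(C(=S)Nc1cccc3ccccc13)C2` gives 20700 nM.
Compound 2 `NC(=O)c1c(NC(=O)c2ccccc2Cl)sc2c1CCN(C(=S)Nc1ccccc1Br)C2` gives 10800 nM.
Compound 3 `NC(=O)c1c(NC(=O)c2ccccc2Cl)sc2c1CCN(C(=S)Nc1ccccc1I)C2` gives 2630 nM.

Of these three, compound 3 gives the lowest number in this assay; the step of a 4.1-fold lower number from compound 2 to compound 3 (0.61 log units; beyond the scatter) and the step of a 7.9-fold lower number from compound 1 to compound 3 (0.90 log units; beyond the scatter) both lie beyond the scatter, so compound 3 stands as the most potent of the three, while the step of a 1.9-fold lower number from compound 1 to compound 2 (0.28 log units; within the scatter) stays within it.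

Compound 4 `NC(=O)c1c(NC(=O)c2ccccc2Cl)sc2c1CCN(C(=S)Nc1ccccc1C(F)(F)F)C2` differs from compound 3 in one place: trifluoromethyl in place of iodo on an aromatic carbon. Within the data shown here, no measured step exchanges iodo for trifluoromethyl, so the steps that bear on this one are those that alter the group at the same place on the ring, a 1.9-fold lower number from compound 1 to compound 2 (0.28 log units; within the scatter) and a 4.1-fold lower number from compound 2 to compound 3 (0.61 log units; beyond the scatter). They show that this position moves the number by small to modest amounts. Trifluoromethyl has no precedent among the measured compounds, so the direction is uncertain; a modest rise from compound 3 is expected, a 2.3-fold higher number from compound 3 to compound 4 (0.36 log units; beyond the scatter). Compound 4 is therefore estimated at 6000 nM, between 2000 nM and 20000 nM.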

Compound 4, half-maximal inhibitory concentration: 1870 nM
For compound 4 the middle estimate is 3.2-fold (0.51 log units) above the measured one, outside the stated range (below it).
By their numbers in this assay, from the lowest: compounds 4 and 3 (each within the scatter of the next); then compounds 2 and 1 (each within the scatter of the next).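

In this assay, trifluoromethyl cannot be told apart from iodo at this place on the ring (a 1.4-fold lower number from compound 3 to compound 4 (0.15 log units; within the scatter)), so two quite different groups, of four heavy atoms and of one, give numbers within the scatter of each other. Against bromo the same group does separate (a 5.8-fold lower number from compound 2 to compound 4 (0.76 log units; beyond the scatter)), and against naphthalen-1-yl it gives the only large step among these compounds (an 11-fold lower number from compound 1 to compound 4 (1.04 log units; beyond the scatter)), which shows that changes on this nitrogen can move the number further than the earlier steps had shown. No measurement shown here accounts for these differences.

The compounds shown leave open whether an amine, a carboxylic acid or a methoxy group at this place would give a number like those of compound 3 and compound 4. They also leave open whether chloro or fluoro would stay with bromo or join iodo and trifluoromethyl.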